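Exchanging the amino linker for an ether in compound 3

The source may report more compounds than this note shows. Statements on the series, on what has been measured and on what is new or still open speak of the compounds shown alone.

Compound 1, `CN(C)CCCNc1ccc(S(=O)(=O)NC(=O)c2ccc(N3CCN(CC4=C(c5ccc(C(F)(F)F)cc5)CC(C)(C)CC4)CC3)cc2Oc2cnc3[nH]ccc3c2)cc1[N+](=O)[O-]`, gives 0.89 nM in an assay on isolated protein for displacement of a labelled ligand from Apoptosis regulator Bcl-2 (Homo sapiens), with a stated time of 15 min; a lower number here means a stronger inhibitor, a higher number a weaker inhibitor. Compound 2, `CC1(C)CCC(CN2CCN(c3ccc(C(=O)NS(=O)(=O)c4ccc(NC5CCOC5)c([N+](=O)[O-])c4)c(Oc4cnc5[nH]ccc5c4)c3)CC2)=C(c2ccc(C(F)(F)F)cc2)C1`, gives 1.9 nM in this assay.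

Among the two measured compounds, compound 2 carries the higher number; its only neighbour is compound 1, and the step of a 2.1-fold higher number from compound 1 to compound 2 (0.33 log units; beyond the scatter) separates them. Compound 3, `CC1(C)CCC(CN2CCN(c3ccc(C(=O)NS(=O)(=O)c4ccc(OCC5CCOCC5)c([N+](=O)[O-])c4)c(Oc4cnc5[nH]ccc5c4)c3)CC2)=C(c2ccc(C(F)(F)F)cc2)C1`, is the next compound in the series and has not yet been tested. It differs from compound 2 by (oxan-4-yl)methoxy in place of (oxolan-3-yl)amino on an aromatic carbon. Among the measured compounds shown here, the single measured step that bears on this change is a 2.1-fold higher number from compound 1 to compound 2 (0.33 log units; beyond the scatter), which exchanged the substituent that compound 3 now alters once more and produced only a modest shift. Since that exchange kept the nitrogen on the aromatic ring while the present one removes it, compound 3 is expected to show a step of a 1.8-fold higher number from compound 2 to compound 3 (0.27 log units; within the scatter) in this assay, a small weakening. Compound 3 is therefore estimated at 3.5 nM in this assay, with a likely range from 1.2 nM to 12 nM.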

Compound 3, half-maximal inhibitory concentration: 1 nM
Estimate against measurement, compound 3: 3.5-fold (0.54 log units) above; measured number outside the range, below it.
By their numbers in this assay, from the lowest: compounds 1, 3 and 2 (each within the scatter of the next, the first and the last beyond it).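

Among the compounds shown here, replacing the (oxolan-3-yl)amino group with (oxan-4-yl)methoxy on this aromatic carbon, ortho to a nitro group, gives a 1.9-fold lower number from compound 2 to compound 3 (0.28 log units; within the scatter) in this assay, so this position accepts an oxygen-linked substituent with no hydrogen-bond donor and a six-membered ring, where the earlier compounds showed only nitrogen-linked groups. The comparison with the charged-free count is equally plain on the other side, with a 1.1-fold higher number from compound 1 to compound 3 (0.05 log units; within the scatter), so the (3-(dimethylamino)propyl)amino group can also give way to (oxan-4-yl)methoxy without a shift beyond the scatter, and the one step beyond it among these three remains the small one between the two nitrogen-linked compounds. Nothing given here explains why the number holds across these exchanges.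

The linking atom, the ring size and the length of the group all change together in the step to compound 3, so their separate contributions remain unresolved. An (oxan-4-yl)methylamino group at this position would isolate the linking atom, and a carboxylic acid on the chain or a longer chain ending in the same oxane ring would show how far this tolerance extends.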